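The compounds below may be only part of what the source reports. "The series", "measured", "known", "first", "only" and "open" are said of these compounds alone.

Measured compounds and their growth inhibition values:

compound 1 `COc1cc(C(=O)N2CCN(C=O)C2=S)cc(OC)c1OC`: in a functional assay on HCC 2998 cells (Homo sapiens) for inhibition, read by sulforhodamine B assay, with a stated time of 48 h (on this read-out lower numbers stand for stronger inhibition of growth and higher numbers for weaker inhibition of growth), compound 1 gives 19800 nM
compound 2 `O=CN1CCN(C(=O)c2ccco2)C1=S`: in this assay compound 2 gives 13400 nM
compound 3 `O=CN1CCN(c2ccc(Cl)cc2)C1=S`: in this assay compound 3 gives 19800 nM

All three numbers sit in the same weak region. Compound 3 is level with compound 1 at the digits shown, and together they carry the highest numbers of the three; compound 2 gives a number that is somewhat lower, yet the gap to compound 3 remains within the usual scatter of this measurement. Within the data shown here, on the numbers alone, no compound stands apart from the others.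

The next compound, compound 4 `O=CN1CCN(c2ccc(Cl)c(Cl)c2)C1=S`, differs from compound 3 by one change: chloro in place of hydrogen on an aromatic carbon. Among the measured compounds shown here, no measured pair in this set isolates such a change, so there is no step to lean on. The three measured compounds, despite quite different substituents on the shared core, all return similar numbers in this assay, which gives little reason to expect a large movement from a single added chloro group.

Compound 4 is therefore expected to stay close to compound 3, with a step of a 1.2-fold lower number from compound 3 to compound 4 (0.09 log units; within the scatter) that is not expected to exceed the scatter. The estimate for compound 4 in this assay is 16000 nM, within a range from 6000 nM to 40000 nM.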

Compound 4, concentration for 50% growth inhibition: 18400 nM
The estimate for compound 4 lay 1.2-fold (0.06 log units) below the measured number; measured number inside the range.
By their numbers in this assay, from the lowest: compounds 2, 4, 1 and 3 (each within the scatter of the next).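

In this assay, chloro in place of hydrogen on an aromatic carbon, ortho to a chloro group and meta to a group of 8 heavy atoms, gives a 1.1-fold lower number from compound 3 to compound 4 (0.03 log units; within the scatter). Among these compounds, this is the first single change that can be read, and it shows that this place on the six-membered aromatic ring takes an added chloro group without a change beyond the scatter, so the number stays in the same weak region. Nothing at hand gives a reason for this result.

One group at one place cannot show whether this place is insensitive to substitution in general, and an amine or a carboxylic acid there could still move the number in either direction. Also open, as far as these compounds go, is whether the same chloro change would stay as small on another aromatic ring of the series, such as the one carried through the carbonyl in compound 1, and whether any change to the shared core itself would lift the series out of this weak region.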